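The source may hold more compounds than are shown below. What is called first, only, known or untested is meant among the compounds shown, and "the series" means these compounds.

In a functional assay on HCT-116 cells (Homo sapiens) for inhibition, read by MTT assay, with a stated time of 72 h (on this read-out higher numbers stand for weaker inhibition and lower numbers for stronger inhibition), three compounds sharing one core have been measured: compound 1 `Cc1ccc(CN2CCc3ncn(COCc4ccccc4)c3/C(=C/c3ccccc3)C2=O)cc1` gives 7940 nM, compound 2 `Cc1cc(C)cc(CN2CCc3ncn(COCc4ccccc4)c3/C(=C/c3ccccc3)C2=O)c1` gives 6230 nM, and compound 3 `O=C1/C(=C\c2ccccc2)c2c(ncn2COCc2ccccc2)CCN1Cc1ccc(Cl)cc1` gives 10500 nM. Compound 3 stands level with the other two, since neither of its steps to them leaves the scatter, so these three compounds cannot be ranked.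

Compound 4 `CC(C)(C)c1ccc(CN2CCc3ncn(COCc4ccccc4)c3/C(=C/c3ccccc3)C2=O)cc1` has not yet been measured. It differs from compound 3 by tert-butyl in place of chloro on an aromatic carbon, para to a large group: tert-butyl in place of chloro on an aromatic carbon.

The most closely related measured change is also a swap on an aromatic carbon, chloro in place of methyl, which gave a 1.3-fold higher number from compound 1 to compound 3 (0.12 log units; within the scatter). The two steps involving the 3,5-dimethylphenyl group, a 1.3-fold lower number from compound 1 to compound 2 (0.11 log units; within the scatter) and a 1.7-fold higher number from compound 2 to compound 3 (0.23 log units; within the scatter), also stay within the scatter. These small steps offer no reason to expect a clear move in either direction in this assay, so no shift beyond the scatter is expected. The expected change is a 1.3-fold lower number from compound 3 to compound 4 (0.12 log units; within the scatter).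

For the measured compounds named here, no measured compound carries tert-butyl, however, so the range has to stay generous. The estimated value for compound 4 is 8000 nM, with an expected range from 3800 nM to 16000 nM.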

Compound 4, half-maximal inhibitory concentration: 8460 nM
Estimate against measurement, compound 4: 1.1-fold (0.02 log units) below, and the stated range covers the measured number.
By their numbers in this assay, from the lowest: compounds 2, 1, 4 and 3 (each within the scatter of the next).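

At this aromatic carbon, para to a large group, replacing chloro (1 heavy atom) with tert-butyl (4 heavy atoms) gives a 1.2-fold lower number from compound 3 to compound 4 (0.09 log units; within the scatter) in this assay, so this larger group produces no readable change. The same holds against the two other substituted rings, with a 1.1-fold higher number from compound 1 to compound 4 (0.03 log units; within the scatter) for the swap from methyl to tert-butyl and a 1.4-fold higher number from compound 2 to compound 4 (0.13 log units; within the scatter) for the swap from 3,5-dimethylphenyl to 4-(tert-butyl)phenyl, so the four compounds cannot be ranked and the range of groups showing no readable difference now extends to tert-butyl. Nothing measured here bears on why the number stays level across these changes.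

On these data alone, the groups compared on this ring are only methyl, chloro and tert-butyl, so it remains open whether an amine, a carboxylic acid or a hydroxyl group on the same carbon would move the number beyond the scatter. The rest of the shared core is identical in all four compounds, so these results also say nothing about how changes elsewhere in the molecule would register in this assay.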